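Trimming the Side Chain: Ethyl to Methyl

The compounds below may be only part of what the source reports. "The series", "measured", "known", "first", "only" and "open" are said of these compounds alone.

Measured compounds: compound 1 `Cc1cc2c(cc1C(=O)N=C(N)N)S(=O)(=O)CC2C(C)C` with 21 nM in an assay on cells for inhibition of sodium/hydrogen exchanger (Oryctolagus cuniculus); a higher number here means a weaker inhibitor, a lower number a stronger inhibitor; compound 2 `Cc1cc2c(cc1C(=O)N=C(N)N)S(=O)(=O)CC2(C)O` with 30 nM; compound 3 `CCC1CS(=O)(=O)c2cc(C(=O)N=C(N)N)c(C)cc21` with 24 nM.

Compound 3 stands second highest of the three numbers; its nearest neighbour is compound 1 and its furthest is compound 2, both within the scatter. Compound 4 `Cc1cc2c(cc1C(=O)N=C(N)N)S(=O)(=O)CC2C` differs from compound 3 by hydrogen in place of methyl on a saturated chain carbon bound to a saturated ring carbon. Among the compounds with values here, the one measured step that bears on this, a 1.1-fold higher number from compound 1 to compound 3 (0.06 log units; within the scatter), removed a methyl from the same kind of chain carbon and stayed within the scatter. A further shortening of the chain is therefore expected to move this assay by no more than the scatter, so the step of a 1.1-fold higher number from compound 3 to compound 4 (0.03 log units; within the scatter) is estimated as essentially flat. Compound 4 is expected to give 26 nM, in the range 12 nM to 55 nM.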

Compound 4, half-maximal inhibitory concentration: 44 nM
Compound 4: the middle estimate sits 1.7-fold (0.23 log units) below what was measured; low and high end bracket the measured number.
By their numbers in this assay, from the lowest: compounds 1, 3, 2 and 4 (each within the scatter of the next, the first and the last beyond it).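

In this assay, ethyl to methyl (a 1.8-fold higher number from compound 3 to compound 4 (0.26 log units; within the scatter)) and hydrogen in place of hydroxy on the saturated ring carbon (a 1.5-fold higher number from compound 2 to compound 4 (0.17 log units; within the scatter)) each stay within the scatter. Methyl in place of isopropyl (a 2.1-fold higher number from compound 1 to compound 4 (0.32 log units; beyond the scatter)) is the first step in this set to pass beyond it, though only modestly, so the group on this ring carbon does register once the span from isopropyl to methyl is read whole. No measured evidence here accounts for that step.

From the compounds shown here alone, it remains open how an amine, a carboxylic acid or a longer chain on this saturated ring carbon would read in this assay. Going by these compounds, it is also open whether the step from isopropyl to methyl would hold on a different core.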